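The source may hold more compounds than are shown below. What is called first, only, known or untested is meant among the compounds shown, and "the series" means these compounds.

Compound 3 `COc1cccc(N2CCN(CCCCCCN3C(=O)c4ccccc4S3(=O)=O)CC2)c1` sits at the weaker end of the three compounds measured in an ADME assay on HEK293 cells for displacement of a labelled ligand from 5-hydroxytryptamine receptor 6 (Homo sapiens), read by radioligand binding, with a stated time of 1 h (a lower number here means a stronger inhibitor, a higher number a weaker inhibitor), where compound 3 gives 921 nM. Compound 1 `O=C1c2ccccc2S(=O)(=O)N1CCCCCCN1CCN(c2cccc(Cl)c2Cl)CC1` gives 920 nM in this assay, and compound 2 `O=C1c2ccccc2S(=O)(=O)N1CCCCCCN1CCN(c2ccc(Cl)c(Cl)c2)CC1` gives 132 nM. Compound 4 `O=C1c2ccccc2S(=O)(=O)N1CCCCCCN1CCN(c2ccccc2)CC1` differs from compound 3 by hydrogen in place of methoxy on an aromatic carbon. Within the data shown here, two measured steps concern substituents on the same aromatic ring: a 1.0-fold higher number from compound 1 to compound 3 (0.00 log units; within the scatter), while a 7.0-fold higher number from compound 2 to compound 3 (0.84 log units; beyond the scatter). Among the measured compounds shown here, changing groups on that ring therefore gave either no step or a modest one, so removing the methoxy is expected to produce at most a modest step, with the direction uncertain, and the estimated step is a 1.3-fold higher number from compound 3 to compound 4 (0.11 log units; within the scatter). Compound 4 is accordingly estimated at 1200 nM, within a range from 450 nM to 3200 nM.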

Compound 4, inhibition constant: 971 nM
Beside the measured number, compound 4's estimate is 1.2-fold (0.09 log units) above it, within the range that was stated.
By their numbers in this assay, from the lowest: compound 2; then compounds 1, 3 and 4 (each within the scatter of the next).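

Among these compounds, removing the methoxy gives no step that can be read in this assay (a 1.1-fold higher number from compound 3 to compound 4 (0.02 log units; within the scatter)), and the bare phenyl also matches the 2,3-dichlorophenyl compound (a 1.1-fold higher number from compound 1 to compound 4 (0.02 log units; within the scatter)). Only the 3,4-dichlorophenyl group stands apart from the bare phenyl (a 7.4-fold higher number from compound 2 to compound 4 (0.87 log units; beyond the scatter)), so among these four compounds, compound 2 is the one case where substitution on this ring moves the number beyond the scatter. No measurement shown here explains this pattern. Still open, from the compounds shown here alone, is whether one chlorine alone would give the step seen with 3,4-dichlorophenyl. Also open, going by these compounds, is how an amino group or a carboxylic acid on this ring would behave.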